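The source may report more compounds than this note shows. Statements on the series, on what has been measured and on what is new or still open speak of the compounds shown alone.

Series of oxazolidinones on a shared core. Compound 1 `C=CCn1ccc(N2C[C@H](CO)OC2=O)c1` gives 625000 nM in an assay for inhibition of Amine oxidase [flavin-containing] B (Bos taurus), read by fluorescence, with a stated time of 30 min; on this read-out lower numbers stand for stronger inhibition and higher numbers for weaker inhibition; compound 2 `Cn1ccc(N2C[C@H](CN=[N+]=[N-])OC2=O)c1` gives 360000 nM in the same assay. Compound 3 `CNC[C@H]1CN(c2ccn(C)c2)C(=O)O1` in this assay is reported only as a limit, > 100000 nM. The step from compound 2 to compound 3 is therefore not readable, a step that the limit leaves unreadable from compound 2 to compound 3, because the limit of > 100000 nM in this assay, at which 1 of the 3 values shown sits, is the limit at which compound 3 sits; the step can only be read as not bringing compound 3 into the measured range.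

Compound 4 `C=CCn1ccc(N2C[C@H](CNC)OC2=O)c1` is the next member, and it differs from compound 3 by vinyl in place of hydrogen on a saturated chain carbon bound to an aromatic nitrogen. Going by the values given here, no measured step isolates this change: compound 1 carries the allyl group but also a hydroxymethyl in place of the methylaminomethyl, so it shows only that an allyl-bearing member of the core sits at 625000 nM, while compound 2 and compound 3 share the methyl group. With compound 3 known only as a limit, the step that the limit leaves unreadable from compound 3 to compound 4 from compound 3 to compound 4 is an expectation without a measured anchor in this assay, and a weak value close to the limit is expected. Compound 4 is estimated at 300000 nM, within 100000 nM to 1000000 nM.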

Compound 4, inhibition constant: 2000 nM
Estimate against measurement, compound 4: 150-fold (2.18 log units) above; the whole stated range lies above it.
By their numbers in this assay, from the lowest: compound 4; then compounds 2 and 1 (each within the scatter of the next).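

Methyl to allyl on a saturated chain carbon bound to an aromatic nitrogen gives an at least 50-fold lower number from compound 3 to compound 4 (1.69 log units; beyond the scatter) in this assay, the first readable sign that this position responds to a change when the methylamino group is present. Compound 3 is reported only as a limit, so the full size of that step stays unknown: the limit of > 100000 nM in this assay, at which 1 of the 4 values shown sits.

With the allyl group held, exchanging the hydroxy group for methylamino gives a 310-fold lower number from compound 1 to compound 4 (2.49 log units; beyond the scatter), so the low number of compound 4 comes only with both groups together, since compound 1 has the allyl group without methylamino and compound 3 has methylamino without the allyl group.

As far as these compounds go, whether the double bond of the allyl group matters, or only the length of the chain, stays open, and a propyl group in its place would separate the two. Also open, from the compounds shown here alone, is how far the methylamino group can be varied, for example to a primary amine or a dimethylamino group, with the allyl group kept on the shared core.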